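Swapping Furan for Thiophene Beside a Benzyl Ester

The source may report more compounds than this note shows. Statements on the series, on what has been measured and on what is new or still open speak of the compounds shown alone.

Compound 1 `CC1=C(C(=O)OCc2ccccc2)C(c2ccco2)NC(=O)N1`: 36%
Compound 2 `CCCOC(=O)C1=C(C)NC(=O)NC1c1cccs1`: 43%
Compound 3 `CC1=C(C(=O)OC(C)(C)C)C(c2cccs2)NC(=O)N1`: 26%

In an assay on membranes from CHO cells for displacement of a labelled ligand from adenosine receptor A1 (Homo sapiens), read by scintillation counting, with a stated time of 60 min, tested at 1 uM (a lower number here means less inhibition, a higher number more inhibition at the concentration tested (going by the name of the read-out)), compound 1 gives 36%, the second highest of the three numbers. Compound 2 gives 43%, which lies within the scatter of compound 1, and compound 3 gives 26%, which also lies within the scatter of compound 1. Going by the values given here, the only step between measured compounds that differ in one place is a number 17 percentage points lower from compound 2 to compound 3 (beyond the scatter), a modest step beyond the scatter, brought about by tert-butyl in place of propyl on an oxygen next to a carbonyl group. That step concerns the ester and says nothing about the five-membered ring.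

Compound 4 `CC1=C(C(=O)OCc2ccccc2)C(c2cccs2)NC(=O)N1` is the unmeasured compound. It differs from compound 1 in one place: thiophen-2-yl in place of furan-2-yl on a saturated ring carbon. Among the compounds with values here, no measured step bears directly on this change. What the numbers do show is that compound 2 and compound 3, both carrying thiophen-2-yl, give values within the scatter of compound 1 with its furan-2-yl. On that basis no step beyond the scatter is expected from thiophen-2-yl in place of furan-2-yl on a saturated ring carbon. Compound 4 is therefore estimated at 36%, with a range from 20% to 52%. This estimate means an expected step of no change at the digits printed from compound 1 to compound 4 (within the scatter).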

Compound 4, a percentage reported as inhibition, at one concentration (the size of the read-out at that concentration, not a potency): 45%
For compound 4 the middle estimate is 9 percentage points below the measured one, within the range that was stated.
By their numbers in this assay, from the lowest: compounds 3, 1, 2 and 4 (each within the scatter of the next, the first and the last beyond it).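

In this assay, going by these compounds alone, the direct exchange of thiophen-2-yl in place of furan-2-yl on a saturated ring carbon, which no earlier pair isolated, gives a number 9 percentage points higher from compound 1 to compound 4 (within the scatter) and so, with the benzyl ester held constant, does not separate the two rings at this position. Within the data shown here, with thiophen-2-yl held constant, benzyl in place of tert-butyl on an oxygen next to a carbonyl group gives a number 19 percentage points higher from compound 3 to compound 4 (beyond the scatter) and phenyl in place of ethyl on a saturated chain carbon bound to that oxygen gives a number 2 percentage points higher from compound 2 to compound 4 (within the scatter), which leaves compound 3 as the one thiophen-2-yl compound set apart from the other two by a step beyond the scatter. Nothing further is available here that would account for these numbers.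

Furan-2-yl appears here only with the benzyl ester, so it remains open whether the two rings would also stay this close with propyl or tert-butyl on that oxygen. From the compounds shown here alone, it is also open how a pyridin-3-yl group on the saturated ring carbon, or a carboxylic acid or an amide in place of the ester, would read in this assay, and each number here is a single-concentration read-out rather than a potency.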